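Swapping an Alkoxy Chain for a Phenyl Ring

The compounds below may be only part of what the source reports. "The series", "measured", "known", "first", "only" and "open" are said of these compounds alone.

Compound 2 `O=C(O)c1cccc(NC(=O)c2cccc(OCC3CC3)c2)c1` carries a cyclopropylmethoxy group on the core it shares with compound 1 `CC(C)CCOc1cccc(C(=O)Nc2cccc(C(=O)O)c2)c1`. Within the data shown here, in an assay on isolated protein for agonist activity at Bile acid receptor (Homo sapiens), read by TR-FRET, with a stated time of 3 h, in the absence of a further agent (on this read-out higher numbers stand for an effect only at larger amounts of compound and lower numbers for an effect already at smaller amounts), compound 2 gives 1260 nM, the lowest of the two numbers measured so far; in this assay compound 1 gives 2760 nM. Among the measured compounds shown here, the single measured step, a 2.2-fold lower number from compound 1 to compound 2 (0.34 log units; beyond the scatter), alters the chain at that same place and gives only a modest shift. Compound 3 `O=C(O)c1cccc(NC(=O)c2cccc(-c3ccccc3)c2)c1` differs from compound 2 by phenyl in place of cyclopropylmethoxy on an aromatic carbon. For the measured compounds named here, no measured step exchanges the cyclopropylmethoxy group for a ring, so the step from compound 1 to compound 2 offers only indirect guidance: a change at this place produced a modest shift. The expected outcome is therefore a step close to the scatter, a 1.3-fold lower number from compound 2 to compound 3 (0.10 log units; within the scatter), without a firm direction. Compound 3 is estimated at 1000 nM in this assay, with a likely range from 300 nM to 4000 nM.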

Compound 3, half-maximal effective concentration: 25 nM
For compound 3 the middle estimate is 40-fold (1.60 log units) above the measured one; the measured number lies below the stated range.
By their numbers in this assay, from the lowest: compound 3; then compound 2; then compound 1.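

Replacing the alkoxy group with a phenyl ring gives a 50-fold lower number from compound 2 to compound 3 (1.70 log units; beyond the scatter) in this assay and, measured against the longer chain, a 110-fold lower number from compound 1 to compound 3 (2.04 log units; beyond the scatter) as well. This position therefore responds far more strongly than the chain change alone had shown, since that change kept the oxygen on the aromatic ring, whereas here the oxygen and the saturated chain both leave and an aromatic ring of carbon only enters. Nothing available explains why this exchange has so large an effect.

The compounds shown leave open whether the phenyl ring itself or the loss of the oxygen accounts for the change, and a benzyloxy group, which holds both an oxygen and a phenyl ring, would help separate the two. On these data alone, how a pyridine ring, or a phenyl ring bearing an amine, would behave at this place also remains open.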